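Chain length and cytotoxicity on HEL cells

This account rests on a few compounds, and the source may have more. Where it says the series, first, only, none or still open, it means among the compounds named here.

Compound 2 `CCCCCCCCc1cc2cn([C@H]3C[C@H](O)[C@@H](CO)O3)c(=O)nc2s1` is one of three compounds that share a core and differ in the saturated chain attached to it. In a functional assay on HEL cells (Homo sapiens) for cytotoxicity (on this read-out lower numbers stand for higher toxicity in this test and higher numbers for lower toxicity in this test), compound 2 gives 53000 nM. Compound 3 `CCCCCCCCCCc1cc2cn([C@H]3C[C@H](O)[C@@H](CO)O3)c(=O)nc2s1` carries a longer chain on the same core, and in this assay compound 3 gives 54000 nM. Compound 1 `CCCCCCCCCCc1cc2cn([C@H]3C[C@H](O)[C@@H](CO)O3)c(=O)nc2o1` carries the longer chain on a core that differs in one ring atom, and in this assay compound 1 reaches only a limit of > 50000 nM, which is a limit of the test and not a number. Among the two numbers shown, compound 2 stands lowest, with compound 3 its nearest neighbour, and that gap is within the scatter.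

Compound 4 `CCCCCCCCCc1cc2cn([C@H]3C[C@H](O)[C@@H](CO)O3)c(=O)nc2s1` differs from compound 2 by methyl in place of hydrogen on a saturated chain carbon, eight bonds along the chain from an aromatic carbon. For the measured compounds named here, the one measured step that bears on this is a 1.0-fold higher number from compound 2 to compound 3 (0.01 log units; within the scatter), which is the same kind of lengthening, cut one bond further out, and it moved nothing beyond the scatter. The step from compound 2 to compound 4 is therefore expected to be no change at the digits printed from compound 2 to compound 4 (within the scatter), with no change beyond the scatter. In this assay compound 4 is estimated at 53000 nM, between 35000 nM and 80000 nM.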

Compound 4, half-maximal cytotoxic concentration: > 20000 nM
Compound 4: no number, only a limit (the forecaster's own chance of this, stated with the estimate: 25%); the middle value lies beyond the limit too.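

In this assay compound 4 gives > 20000 nM, which is a limit of the test and not a number, so the steps to compound 4 from compound 2 and from compound 3 cannot be read. The compounds shown leave open whether the chain of compound 4 sets it apart from compound 2 and compound 3 in this assay.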